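This account rests on a few compounds, and the source may have more. Where it says the series, first, only, none or still open, it means among the compounds named here.

Of the compounds shown here, three that share one core have been tested in a functional assay on KB cells (Homo sapiens) for cytotoxicity, read by MTT assay, with a stated time of 72 h; on this read-out higher numbers stand for an effect only at larger amounts of compound and lower numbers for an effect already at smaller amounts. Compound 1 `O=C1/C(=C\c2c(Cl)cccc2Cl)c2ccccc2N1c1c(Cl)cccc1Cl` gives 50 ug/mL in this assay, compound 2 `O=C1/C(=C\c2ccc(O)cc2)c2ccccc2N1c1c(Cl)cccc1Cl` gives 2 ug/mL, and compound 3 `O=C1/C(=C\c2ccc(F)cc2)c2ccccc2N1c1c(Cl)cccc1Cl` gives 5 ug/mL. Compound 3 therefore holds the second highest of the three numbers: a 2.5-fold higher number from compound 2 to compound 3 (0.40 log units; beyond the scatter), while a 10-fold lower number from compound 1 to compound 3 (1.00 log units; beyond the scatter).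

Compound 4 `CN(C)c1ccc(/C=C2\C(=O)N(c3c(Cl)cccc3Cl)c3ccccc32)cc1` has not yet been measured in this assay. It differs from compound 3 in one place: dimethylamino in place of fluoro on an aromatic carbon.

Two kinds of measured step bear on this change. Replacing the whole phenyl group on the double-bonded chain carbon gave a 25-fold lower number from compound 1 to compound 2 (1.40 log units; beyond the scatter) and a 10-fold lower number from compound 1 to compound 3 (1.00 log units; beyond the scatter), both large or modest moves. The smaller exchange of one group on an aromatic carbon, the kind of change now in question, gave a 2.5-fold higher number from compound 2 to compound 3 (0.40 log units; beyond the scatter). Given that compound 2 sits lower than compound 3, as seen in a 2.5-fold higher number from compound 2 to compound 3 (0.40 log units; beyond the scatter), a modest step toward a lower number is expected for compound 4, a 1.7-fold lower number from compound 3 to compound 4 (0.22 log units; within the scatter), although a step within the scatter would not be surprising. Compound 4 is estimated to give 3 ug/mL in this assay, with a likely range from 1 ug/mL to 10 ug/mL.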

Compound 4, concentration for half-maximal effect: 15 ug/mL
The estimate for compound 4 lay 5.0-fold (0.70 log units) below the measured number, and the stated range ends below it.
By their numbers in this assay, from the lowest: compound 2; then compound 3; then compound 4; then compound 1.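

In this assay, dimethylamino in place of fluoro on this aromatic carbon, para to a large group, gives a 3.0-fold higher number from compound 3 to compound 4 (0.48 log units; beyond the scatter), and dimethylamino in place of hydroxy gives a 7.5-fold higher number from compound 2 to compound 4 (0.88 log units; beyond the scatter). Among the compounds shown here, the earlier compounds showed only one exchange at this position, whereas three groups now give three separate numbers, rising from hydroxy through fluoro to dimethylamino, so the position is more sensitive to the group it carries than that single step could show. The 4-(dimethylamino)phenyl group still gives a 3.3-fold lower number from compound 1 to compound 4 (0.52 log units; beyond the scatter) when it stands in place of 2,6-dichlorophenyl, so like the 4-hydroxyphenyl and 4-fluorophenyl groups it keeps a lower number, and nothing at hand explains why these groups fall in this order.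

As far as these compounds go, with only hydroxy, fluoro and dimethylamino at this position, it remains open where a methoxy group, a plain amino group or a carboxylic acid would fall in that order. From the compounds shown here alone, it is also open whether the same order would hold with these groups on another carbon of the same ring.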